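Weak Growth Inhibition Across a Shared Core

The source may report more compounds than this note shows. Statements on the series, on what has been measured and on what is new or still open speak of the compounds shown alone.

Compound 1 `COc1cc2c(=O)c(C(=O)c3ccc(C)cc3)cn(Cc3ccc(C(F)(F)F)cc3F)c2cc1OC`: > 25000 nM
Compound 2 `COc1cc2c(=O)c(C(=O)c3ccc(C)cc3)cn(Cc3ccc(Cl)c(Cl)c3)c2cc1OC`: "not active" (no number reported)
Compound 3 `COc1cc2c(=O)c(C(=O)OCc3ccccc3C)cn(Cc3ccc(C(F)(F)F)cc3F)c2cc1OC`: 31000 nM

All three were tested in an ADME assay on Huh-7 cells (Homo sapiens) for cytotoxicity; on this read-out lower numbers stand for stronger inhibition of growth and higher numbers for weaker inhibition of growth. Compound 1 gives > 25000 nM, which is a limit of the assay and not a number. Compound 2 is reported only as not active, with no number given. Compound 3 gives 31000 nM. For the measured compounds named here, the one measured step, a step that the limit leaves unreadable from compound 1 to compound 3, changes a group on a carbonyl carbon and is unreadable due to the limit of > 25000 nM in this assay, at which 1 of the 3 values shown sits; it does not touch the place changed here. Compound 4 `COc1cc2c(=O)c(C(=O)c3ccc(C)cc3)cn(CCCc3ccccc3)c2cc1OC` differs from compound 2 in phenethyl in place of 3,4-dichlorophenyl on a saturated chain carbon bound to an aromatic nitrogen. Going by the values given here, no measured step covers this change, so neither a direction nor a size can be read from the data. Compound 4 is expected to remain weak, estimated at 30000 nM (range 10000 nM to 100000 nM), quite possibly reported again only as a limit.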

Compound 4, concentration for 50% growth inhibition: "not active" (no number reported)
Compound 4 has no reported number here, so the estimate cannot be set against anything.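

Compound 2 and compound 4 are both reported only as not active, with no number, and no new step can be read from them. From the compounds shown here alone, the size of any effect of replacing 3,4-dichlorobenzyl with 3-phenylpropyl in this assay stays open.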